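The compounds below may be only part of what the source reports. "The series", "measured", "known", "first", "only" and "open" are said of these compounds alone.

Of the compounds shown here, three built on one shared core have been measured in an assay on isolated protein for binding affinity to corticotropin-releasing factor receptor 1 (Homo sapiens); on this read-out higher numbers stand for weaker inhibition and lower numbers for stronger inhibition. Compound 1 `CCCN(CC1CC1)c1nc(C)nc(N(CC)c2ccc(N(C)C)cc2C(F)(F)F)n1` gives 5 nM. Compound 2 `CCN(CC)c1nc(C)nc(N(CC)c2ccc(N(C)C)cc2Br)n1` gives 6 nM, and the gap between this number and that of compound 1 lies within the usual scatter of repeated measurements, so the two compounds stand together rather than apart. Compound 3 `CCN(CC)c1nc(C)nc(N(CC)c2ccc(C(C)C)cc2Br)n1`, which carries an isopropyl group in place of the dimethylamino group, was measured twice; in this assay compound 3 gives 27 nM; 27 nM (2 entries).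

Compound 4 `CCN(CC)c1nc(C)nc(N(CC)c2ccc(N(C)C)cc2C(F)(F)F)n1` has not yet been measured. It arises from compound 2 by trifluoromethyl in place of bromo on an aromatic carbon. Within the data shown here, no measured pair shows this exchange alone: compound 1, which also carries trifluoromethyl, and compound 2, which carries bromo, give numbers within the scatter of each other, but they differ at a second place as well. The step from compound 2 to compound 4 is therefore expected to be small, a 1.2-fold lower number from compound 2 to compound 4 (0.08 log units; within the scatter), in neither direction beyond the scatter. For compound 4 the estimated value is 5 nM, with a likely range from 2 nM to 15 nM.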

Compound 4, inhibition constant: 20 nM
For compound 4 the middle estimate is 4.0-fold (0.60 log units) below the measured one, outside the stated range (above it).
By their numbers in this assay, from the lowest: compounds 1 and 2 (each within the scatter of the next); then compound 4.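

In this assay, the exchange of bromo for trifluoromethyl on this aromatic carbon can now be read on its own, and it is not neutral: a 3.3-fold higher number from compound 2 to compound 4 (0.52 log units; beyond the scatter). With trifluoromethyl held in place, the amine on the shared core also matters, as diethylamino in place of (cyclopropylmethyl)(propyl)amino gives a 4.0-fold higher number from compound 1 to compound 4 (0.60 log units; beyond the scatter). No measurement shown here gives a reason for either step.

The compounds shown leave open how chloro, methyl or a nitrile at this same place would compare with bromo and trifluoromethyl. They also leave open whether (cyclopropylmethyl)(propyl)amino in place of diethylamino would shift the number in the same way when bromo, rather than trifluoromethyl, sits on the aromatic ring.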